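The source may report more compounds than this note shows. Statements on the series, on what has been measured and on what is new or still open speak of the compounds shown alone.

Of the compounds shown here, two have so far been measured in a functional assay on A549 cells (Homo sapiens) for antiproliferative activity, read by CCK-8 assay, with a stated time of 72 h; a lower number here means a stronger inhibitor, a higher number a weaker inhibitor. Compound 1 `O=C(/C=C/c1ccc(CN2CCc3ccccc32)cc1)NO` gives 5480 nM, and compound 2 `CCCc1ccc(OCc2ccc(C(=O)Nc3ccccc3N)cc2)cc1` gives 5210 nM. For the measured compounds named here, these two values lie within the scatter of each other, so neither compound stands apart and compound 1 sits level with the only other measured compound. The next compound, compound 3 `Nc1ccccc1NC(=O)/C=C/c1ccc(CN2CCc3ccccc32)cc1`, keeps the core of compound 1 and changes one group: 2-aminophenyl in place of hydroxy on an amide-type nitrogen. In words, a 2-aminophenyl takes the place of hydroxy on an amide-type nitrogen.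

Going by the values given here, no pair of measured compounds differs in one place, so the size of this change has not been observed directly. Among the compounds with values here, the only guide is compound 2, which also carries a 2-aminophenyl on an amide-type nitrogen and gives 5210 nM on a different scaffold. On that thin evidence, no step beyond the scatter is expected in this assay, though the uncertainty is wide in both directions. The expected step is a 1.1-fold lower number from compound 1 to compound 3 (0.04 log units; within the scatter). For compound 3 the estimated value is 5000 nM, with an expected range from 1500 nM to 16000 nM.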

Compound 3, half-maximal inhibitory concentration: 13400 nM
Estimate against measurement, compound 3: 2.7-fold (0.43 log units) below; low and high end bracket the measured number.
By their numbers in this assay, from the lowest: compounds 2 and 1 (each within the scatter of the next); then compound 3.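

For the compounds shown here, this is the first direct reading of a change at this place, on the amide-type nitrogen of the shared core. In this assay, 2-aminophenyl in place of hydroxy gives a modest change (a 2.4-fold higher number from compound 1 to compound 3 (0.39 log units; beyond the scatter)), and this step lies beyond the scatter. The position therefore does not tolerate every group equally on this core: the exchange costs some activity even though the two groups carry the same count of hydrogen-bond donors and acceptors, with seven heavy atoms entering where one leaves. Nothing measured here accounts for the step.

This single pair leaves open whether the loss follows the added bulk, the aromatic ring or the amino group on that ring, and a plain phenyl, a 2-hydroxyphenyl or a methyl on the same nitrogen would help to separate these readings. Going by these compounds alone, it also remains open whether the same exchange would give a step of similar size on a different core, as only one such pair can be read so far.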